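Methoxy removal on the carbonyl aryl of compound 2

The compounds below may be only part of what the source reports. "The series", "measured", "known", "first", "only" and "open" are said of these compounds alone.

In a functional assay on NCI/ADR-RES cells (Homo sapiens) for cytotoxicity, read by sulforhodamine B assay, with a stated time of 48 h, tested at 100 uM (on this read-out lower numbers stand for a stronger effect and higher numbers for a weaker effect at the one concentration tested), compound 2 `COc1ccc(C(=O)/C=C/c2cc(-c3cc(OC)c(OC)c(OC)c3)n[nH]2)cc1OC` gives -40%, the lowest of the two numbers recorded. Compound 1 `COc1cc(-c2cc(/C=C/C(=O)c3ccc(N)cc3)[nH]n2)cc(OC)c1OC` gives -3%. Among the measured compounds shown here, the one measured step, a number 37 percentage points lower from compound 1 to compound 2 (beyond the scatter), shows that the aryl on the carbonyl carbon moves this read-out strongly. Compound 3 `COc1ccc(C(=O)/C=C/c2cc(-c3cc(OC)c(OC)c(OC)c3)n[nH]2)cc1` differs from compound 2 by hydrogen in place of methoxy on an aromatic carbon. For the measured compounds named here, no measured step covers a methoxy removal, so the expectation rests loosely on the size of that aryl step. The estimated change is a number 20 percentage points higher from compound 2 to compound 3 (beyond the scatter), a partial loss of effect. Compound 3 is expected at -20%, range -45% to 5%.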

Compound 3, a percentage reported as activity, at one concentration (the size of the read-out at that concentration, not a potency): -6%
For compound 3 the middle estimate is 14 percentage points below the measured one; measured number inside the range.
By their numbers in this assay, from the lowest: compound 2; then compounds 3 and 1 (each within the scatter of the next).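

In this assay, a single methoxy ortho to a methoxy group carries a large share of the effect: a number 34 percentage points higher from compound 2 to compound 3 (beyond the scatter), as 3,4-dimethoxyphenyl becomes 4-methoxyphenyl. The aryl step is thus not a general gain from any methoxy, since a number 3 percentage points lower from compound 1 to compound 3 (within the scatter), leaving 4-methoxyphenyl and 4-aminophenyl on the carbonyl carbon indistinguishable here. Nothing available explains why this methoxy matters. Still open, from the compounds shown here alone, is whether a hydroxyl, a fluorine or an ethoxy on this aromatic carbon would keep the effect of compound 2.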